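The source may hold more compounds than are shown below. What is called first, only, known or untested is meant among the compounds shown, and "the series" means these compounds.

Compound 1 `CC/C(=C(/c1ccc(/C=C/C(=O)O)cc1)c1ccc2[nH]ncc2c1)c1ccccc1`: 7.2 nM
Compound 2 `CC/C(=C(/c1ccc(/C=C/C(=O)O)cc1)c1ccn2nccc2c1)c1ccccc1`: > 500 nM (a limit)
Compound 3 `CC/C(=C(/c1ccc(/C=C/C(=O)O)cc1)c1ccc2scnc2c1)c1ccccc1`: 90 nM

These values come from a functional assay on MCF7 cells (Homo sapiens) for antiproliferative activity, read by CellTiter-Glo, with a stated time of 5 days; on this read-out lower numbers stand for stronger inhibition and higher numbers for weaker inhibition. Compound 2 stands at a limit of the assay and not at a true number: > 500 nM. Compound 3 holds the higher of the two true numbers, with a 13-fold higher number from compound 1 to compound 3 (1.10 log units; beyond the scatter).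

Compound 4 `CC/C(=C(/c1ccc(/C=C/C(=O)O)cc1)c1ccc2sncc2c1)c1ccccc1` differs from compound 3 only on a double-bonded chain carbon bound to an aromatic carbon and a double-bonded chain carbon: a group of 9 heavy atoms (7 carbon, 1 nitrogen, 1 sulfur; one five-membered aromatic ring with 2 hetero atoms, one six-membered aromatic ring of carbon only) in place of a group of 9 heavy atoms (7 carbon, 1 nitrogen, 1 sulfur; one five-membered aromatic ring with 2 hetero atoms, one six-membered aromatic ring of carbon only), on a double-bonded chain carbon bound to an aromatic carbon and a double-bonded chain carbon. The two have the same atoms, joined differently.

Within the data shown here, all the measured steps swap a group at this same place, and they are large: an at least 69-fold higher number from compound 1 to compound 2 (1.84 log units; beyond the scatter), and an at least 5.5-fold lower number from compound 2 to compound 3 (0.74 log units; beyond the scatter). The groups in the first of these also match in their counted atoms, so a change in how atoms are joined can matter in this series. Among the measured compounds shown here, no measured step shows this exact change, however, so its direction remains open. The expected step, a 1.3-fold lower number from compound 3 to compound 4 (0.11 log units; within the scatter), is therefore an uncertain estimate with a wide range. For compound 4 the estimated value is 70 nM, with an expected range from 15 nM to 300 nM.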

Compound 4, half-maximal inhibitory concentration: > 500 nM
Compound 4 gave a limit, no number; the forecaster's own chance of this, stated with the estimate: 8%; at least 7.1-fold (0.85 log units) between middle value and limit.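

Compound 4 stands at a limit of this assay, not at a true number: > 500 nM. Swapping 1,3-benzothiazol-5-yl for its partner with the same atoms, joined differently, on the double-bonded chain carbon gives an at least 5.5-fold higher number from compound 3 to compound 4 (0.74 log units; beyond the scatter), so this exact change in how the atoms are joined now has a measured direction, and the gap to the core of compound 1 is also wide, with an at least 69-fold higher number from compound 1 to compound 4 (1.84 log units; beyond the scatter). The step between compound 2 and compound 4 cannot be read, as both values are limits: the limit of > 500 nM in this assay, at which 2 of the 4 values shown sit.

Going by these compounds, how far compound 2 and compound 4 lie past that limit remains unknown. Also open, on these data alone, is how a different group on this same carbon, such as 1H-indol-5-yl or a simple amine, would compare with the 1H-indazol-5-yl group of compound 1.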